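An allylthiourea in place of a cyanoguanidine

The source may hold more compounds than are shown below. What is called first, only, known or untested is meant among the compounds shown, and "the series" means these compounds.

Compound 2 `N#CNC(=N)NCCCCCn1nc(-c2ccccc2)ccc1=O` was examined in a functional assay on the whole organism (stomach) with Rattus norvegicus as the target; a higher number here means that more compound is needed for the effect, a lower number that less compound is needed. For compound 2 the result is only a limit of the measurement, > 100 mg/kg. Compound 1 `C/N=C(\S)NCCCCn1nc(C)ccc1=O` likewise reaches only a limit, > 100 mg/kg. Compound 3 `C/N=C(/NC#N)NCCCCn1nc(-c2ccc(Cl)cc2)ccc1=O` gives 100 mg/kg in this assay. The values gather at the limit of > 100 mg/kg in this assay, at which 2 of the 3 values shown sit, and compound 2 is among them, standing at the edge of what this assay reports rather than at a number. Compound 4 `C=CCNC(=S)NCCCCn1nc(-c2ccccc2)ccc1=O` has not been measured in this assay. It differs from compound 2 by a group of 7 heavy atoms (4 carbon, 2 nitrogen, 1 sulfur; no ring) in place of a group of 7 heavy atoms (3 carbon, 4 nitrogen; no ring), on a saturated chain carbon, four bonds along the chain from an aromatic nitrogen. Among the measured compounds shown here, no measured pair traces a comparable change, so the expected step is none beyond the scatter, and the estimated step is a number no higher from compound 2 to compound 4 (the limit leaves the size open). Compound 4 is therefore expected to give about 100 mg/kg in this assay, within 30 mg/kg to 300 mg/kg.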

Compound 4, dose for half-maximal effect: > 100 mg/kg
Compound 4: a limit, no number; the forecaster's own chance of this, stated with the estimate: 60%; the middle value sits exactly at the limit.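

Compound 2 and compound 4 both end at a limit rather than a number, so no step between them can be read: the limit of > 100 mg/kg in this assay, at which 3 of the 4 values shown sit.

The compounds shown leave open whether the allylthiourea of compound 4 and the cyanoguanidine of compound 2 differ at all in the dose needed.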